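One Aryl Swap, One Expected Maximal Response

The compounds below may be only part of what the source reports. "The series", "measured", "known", "first", "only" and "open" are said of these compounds alone.

Measured in an in vitro functional assay on HEK285-7 cells for antagonist activity at prostaglandin D2 receptor 2 (Homo sapiens), read by BRET and beta-arrestin recruitment; a lower number here means a smaller maximal response, a higher number a larger maximal response:
Compound 1 `NS(=O)(=O)c1ccc(-c2nc(C(c3ccc(F)cc3)c3ccc(F)cc3)sc2CC(=O)O)cc1`: 80%
Compound 2 `O=C(O)Cc1sc(COc2ccc(Cl)cc2)nc1-c1ccc(Cl)cc1`: 50%
Compound 3 `O=C(O)Cc1sc(C(c2ccccc2)c2ccccc2)nc1-c1ccc(F)c(F)c1`: 80%

Compound 1 and compound 3 are level at the digits shown and together sit at the top of these three numbers; compound 2 stands lower, by a gap beyond the usual scatter. Compound 4 `O=C(O)Cc1sc(C(c2ccc(F)cc2)c2ccc(F)cc2)nc1-c1ccnc(F)c1` differs from compound 1 in one place: 2-fluoropyridin-4-yl in place of 4-sulfamoylphenyl on an aromatic carbon. For the measured compounds named here, no pair of measured compounds isolates this change, so the expectation rests on how little the shared core seems to care which aromatic group sits there, as compound 1 and compound 3 show. For compound 4 a small step is expected in this assay, downward if anything and within the scatter: a number 5 percentage points lower from compound 1 to compound 4 (within the scatter). Compound 4 is therefore estimated at 75%, between 55% and 90%.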

Compound 4, largest response reached (reported as efficacy), in percent of the reference or control that the assay uses: 80%
Beside the measured number, compound 4's estimate is 5 percentage points below it; the measured number falls inside the stated range.
By their numbers in this assay, from the lowest: compound 2; then compounds 1, 3 and 4 (each within the scatter of the next).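

In this assay, putting 2-fluoropyridin-4-yl in place of 4-sulfamoylphenyl gives no change at the digits printed from compound 1 to compound 4 (within the scatter). For the compounds shown here, this is the first pair that isolates this position, and it shows that the response holds even though the entering group has a hetero atom in its ring and no hydrogen-bond donor. Nothing measured here explains why the two groups match. From the compounds shown here alone, whether the position needs an aromatic ring at all remains open, since a cyclohexyl ring or a plain methyl group there would test that directly.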